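Swapping an Aryl Ether for Cyclohexylmethyl: Solubility Outlook

A few compounds are considered here, and "the series" means these few. Any claim that something is new, unique, unknown or untested is made for them only; others in the source may bear on it.

Going by the values given here, compound 2 `COc1ccccc1Oc1ccc2c(NCCCNCc3cccc(OC)c3O)ccnc2c1` has the higher of the two solubility numbers measured so far: in a physicochemical assay for solubility, with a stated time of 18 h, at pH 7.4 (a higher number here means a more soluble compound, a lower number a less soluble compound), compound 2 gives 14500 nM. Among the compounds with values here, its nearest neighbour, compound 1 `COc1cccc(CNCCCNc2ccnc3cc(CCC(C)C)ccc23)c1O`, gives 4200 nM in this assay, and the one step measured so far, a 3.5-fold higher number from compound 1 to compound 2 (0.54 log units; beyond the scatter), came with 2-methoxyphenoxy in place of isopentyl on an aromatic carbon. Compound 3 `COc1cccc(CNCCCNc2ccnc3cc(CC4CCCCC4)ccc23)c1O` has not yet been measured. It differs from compound 2 in one place: cyclohexylmethyl in place of 2-methoxyphenoxy on an aromatic carbon. Within the data shown here, the only step that bears on this is the one from compound 1 to compound 2, which ran in the opposite sense, removing isopentyl in favour of 2-methoxyphenoxy; compound 3 instead brings in cyclohexylmethyl. A downward step of roughly that size is therefore expected, a 4.1-fold lower number from compound 2 to compound 3 (0.62 log units; beyond the scatter), beyond the scatter. Compound 3 is estimated at 3500 nM in this assay, within 1200 nM to 10000 nM.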

Compound 3, solubility: 4200 nM
Compound 3: middle estimate off by 1.2-fold (0.08 log units), on the low side, within the range that was stated.
By their numbers in this assay, from the lowest: compounds 1 and 3 (each within the scatter of the next); then compound 2.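

In this assay, replacing one carbon-only group with another at this position gives no change at the digits printed from compound 1 to compound 3 (within the scatter), even though the isobutyl part becomes cyclohexyl. Replacing the aryl ether gives a 3.5-fold lower number from compound 2 to compound 3 (0.54 log units; beyond the scatter), so among these three compounds only compound 2, with 2-methoxyphenoxy, stands apart from the two carbon-only groups. No supporting measurement is available to explain these numbers.

The change from compound 2 to compound 3 swaps an aromatic ring for a non-aromatic one and also removes the ether oxygens, and these compounds cannot separate those two differences. Going by these compounds, how a plain phenoxy group, a cyclohexyloxy group or a morpholine at this position would compare remains open.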